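Cytotoxicity notes on a piperidine-carboxamide series

The source may hold more compounds than are shown below. What is called first, only, known or untested is meant among the compounds shown, and "the series" means these compounds.

Measured so far:
compound 1 `O=C(Nc1ccc(Cl)cc1)C1CCCN(C(=O)c2cccc(-c3cccs3)c2)C1` — 4%
compound 2 `COC(=O)c1cc(-c2cccc(NC(=O)C3CCCN(C(=O)c4cc(C(F)(F)F)cc(C(F)(F)F)c4)C3)c2)co1` — 0%
compound 3 `O=C(Nc1ccc(Cl)nc1)C1CCCN(C(=O)c2cc(C(F)(F)F)cc(C(F)(F)F)c2)C1` — 25%

Three compounds have been run in an ADME assay on PC-3 cells (Homo sapiens) for cytotoxicity, read by WST assay, tested at 100 uM; on this read-out higher numbers stand for more inhibition at the one concentration tested (going by the name of the read-out) and lower numbers for less inhibition. Compound 3 gives 25%, the highest of the three numbers. Compound 1 stands second with 4%, but its nearest neighbour is compound 2, and the gap between those two lies within the scatter, so no order between compound 1 and compound 2 can be read from these numbers; only the gap from compound 1 up to compound 3 lies beyond the scatter.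

The next compound, compound 4 `O=C(Nc1ccc(Cl)cc1)C1CCCN(C(=O)c2cccc([N+](=O)[O-])c2)C1`, differs from compound 1 in one place: nitro in place of thiophen-2-yl on an aromatic carbon. Nothing else in the shared core moves. For the measured compounds named here, no measured pair shows the effect of this change, and the three measured numbers all sit low apart from compound 3. On that footing no step beyond the scatter is expected in this assay for compound 4; the number is estimated close to that of compound 1, with the step of a number 2 percentage points higher from compound 1 to compound 4 (within the scatter) expected to stay inside the usual spread. Compound 4 is therefore estimated at 6%, with a range from -5% to 20%.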

Compound 4, a percentage reported as inhibition, at one concentration (the size of the read-out at that concentration, not a potency): 0%
Beside the measured number, compound 4's estimate is 6 percentage points above it, and the stated range covers the measured number.
By their numbers in this assay, from the lowest: compounds 2, 4 and 1 (each within the scatter of the next); then compound 3.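

In this assay, for the compounds shown here, nitro in place of thiophen-2-yl on an aromatic carbon gives a number 4 percentage points lower from compound 1 to compound 4 (within the scatter) and is the first step read at this position, on a six-membered aromatic ring of carbon only, meta to a large group. Replacing a five-membered aromatic ring with 1 hetero atom and 5 heavy atoms by a group with no ring and 3 heavy atoms therefore does not separate the two compounds at the one concentration tested. No measurement at hand bears on this result.

Still open, as far as these compounds go, is whether an amine or a carboxylic acid on this aromatic carbon would give a step beyond the scatter. Also open, from the compounds shown here alone, is whether the same exchange gives a similar step when the anilide part of the molecule differs.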